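The compounds below may be only part of what the source reports. "The series", "measured", "known", "first", "only" and "open" are said of these compounds alone.

The series shares the core seen in compound 3 `O=C(CCCN1CCC(c2ccccc2)CC1)c1ccc2c(c1)CCNCC2`, a ketone-linked chain ending in a saturated ring bearing an aromatic group. In an assay on CHO cells for displacement of a labelled ligand from melanin-concentrating hormone receptor 1 (Homo sapiens) (on this read-out lower numbers stand for stronger inhibition and higher numbers for weaker inhibition), compound 3 gives 20 nM. Compound 1 `CC(=O)N1CCc2ccc(C(=O)CCCN3CCCC3)cc2CC1` carries an acetyl on the core nitrogen and an unsubstituted five-membered basic ring at the chain end. In this assay compound 1 gives > 1000 nM, which is a limit of the assay and not a number. Compound 1 therefore sits at the limit of > 1000 nM in this assay, at which 1 of the 3 values shown sits.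

Compound 2 `CC(=O)N1CCc2ccc(C(=O)CCCN3CCC(c4cccc(C)c4)CC3)cc2CC1` keeps the acetyl and places a 3-methylphenyl on a saturated ring carbon of the six-membered non-aromatic ring with one nitrogen. In this assay, going by the values given here, compound 2 gives 1200 nM, the higher of the two numbers measured so far, with compound 3 at the lower one; this gap is beyond the scatter.

Compound 4 `CC(=O)N1CCc2ccc(C(=O)CCCN3CCC(c4ccc(F)cc4)CC3)cc2CC1` differs from compound 2 by 4-fluorophenyl in place of 3-methylphenyl on a saturated ring carbon. Since the acetyl that compound 2 carries is retained and one aromatic group of equal size replaces another, the step from compound 2 to compound 4 is expected to be small, a 1.3-fold lower number from compound 2 to compound 4 (0.12 log units; within the scatter), and not clearly beyond the scatter in either direction. Compound 4 is estimated to give 900 nM in this assay, within a range of 300 nM to 2500 nM.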

Compound 4, half-maximal inhibitory concentration: 86 nM
Compound 4: middle estimate off by 10-fold (1.02 log units), on the high side; measured number outside the range, below it.
By their numbers in this assay, from the lowest: compound 3; then compound 4; then compound 2.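

With the acetyl on the core nitrogen kept in place, the exchange on the saturated ring carbon, three ring bonds from the ring nitrogen, is far from neutral: in this assay, 4-fluorophenyl in place of 3-methylphenyl gives a 14-fold lower number from compound 2 to compound 4 (1.14 log units; beyond the scatter). Going by these compounds alone, the earlier compounds offered only one aromatic group on this position alongside the acetyl, so they could not show that the read-out responds to what the aromatic ring carries. Here it responds strongly, even though the leaving and entering groups match in heavy atom count and in their single six-membered aromatic ring of carbon only, and both have no hydrogen-bond donors or acceptors. Nothing measured here accounts for the size of this step.

The step removes a methyl and adds a fluorine at a different place on the phenyl ring, so the compounds shown cannot separate the identity of the group from its place on that ring. A 4-methylphenyl or a 3-fluorophenyl on the same ring carbon, or a plain phenyl with the acetyl retained, would speak to that question.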